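The source may report more compounds than this note shows. Statements on the series, on what has been measured and on what is new or still open speak of the compounds shown alone.

Compound 1 `N#Cc1ccc(C2OCC(C/C=C\CCC(=O)O)C(c3cccnc3)O2)cc1` – in an assay for inhibition of prostacyclin synthase (Homo sapiens), using microsomes (a higher number here means a weaker inhibitor, a lower number a stronger inhibitor), compound 1 is recorded only as a limit, > 100000 nM.
Compound 2 `O=C(O)CC/C=C\CC1COC(c2ccc(Cl)cc2Cl)OC1c1cccnc1` – in this assay compound 2 gives 2500 nM.

Compound 1 therefore stands at the limit of this assay, and only that limit is known for it; (the limit of > 100000 nM in this assay, at which 1 of the 2 values shown sits). Among the measured compounds shown here, the one measured step, an at least 40-fold lower number from compound 1 to compound 2 (1.60 log units; beyond the scatter), exchanges the group on the saturated ring carbon between the two ring oxygen atoms.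

Compound 3 `CC(C)(Oc1ccccc1)C1OCC(C/C=C\CCC(=O)O)C(c2cccnc2)O1` differs from compound 1 at the same place: a group of 10 heavy atoms (9 carbon, 1 oxygen; one six-membered aromatic ring of carbon only) in place of a group of 8 heavy atoms (7 carbon, 1 nitrogen; one six-membered aromatic ring of carbon only), on a saturated ring carbon. For the measured compounds named here, no measured step covers this new group itself; the only bearing comes from the step from compound 1 to compound 2, which shows that a change at this position can move the number by a large amount. On that basis a lower number for compound 3 than for compound 1 is expected, an at least 5.0-fold lower number from compound 1 to compound 3 (0.69 log units; beyond the scatter), though with wide uncertainty since compound 1 itself is only a limit. The estimate for compound 3 in this assay is 20000 nM, within a range from 3000 nM to 100000 nM.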

Compound 3, half-maximal inhibitory concentration: 75000 nM
Beside the measured number, compound 3's estimate is 3.8-fold (0.57 log units) below it, within the range that was stated.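

At the saturated ring carbon between two ring oxygen atoms, the group of 10 heavy atoms in place of 2,4-dichlorophenyl gives back much of the earlier drop in this assay, a 30-fold higher number from compound 2 to compound 3 (1.48 log units; beyond the scatter), so this position is now seen to move the number strongly in both directions. All three groups carry a six-membered aromatic ring of carbon only, which shows that this ring alone does not set the number; the comparison with the nitrile-bearing group reads only as an at least 1.3-fold lower number from compound 1 to compound 3 (0.12 log units; that floor lies within the scatter), and that floor lies within the scatter, so it gives no order between those two compounds. Compound 1 remains a limit, and the true size of its step stays unfixed: the limit of > 100000 nM in this assay, at which 1 of the 3 values shown sits.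

Open, going by these compounds, is whether a plain phenyl or a single chlorine on the phenyl would read nearer to compound 2 or to compound 3. Also open, on these data alone, is how an amine or a carboxylic acid at this ring carbon would read in this assay, and whether these steps hold with a chain other than the 5-carboxypent-2-en-1-yl group.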